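Replacing a Methoxypropyl Amide with a Carboxylic Acid Side Chain

This account rests on a few compounds, and the source may have more. Where it says the series, first, only, none or still open, it means among the compounds named here.

Measured compounds:
compound 1, `CC(C)(C)[C@H]1CC[C@H](N(Cc2ccc(C(=O)NCCC(=O)O)cc2)C(=O)Nc2ccc(OCC3CC3)cc2)CC1`, 140 nM
compound 2, `COCCCNC(=O)c1ccc(CN(C(=O)Nc2ccc(OC(F)(F)F)cc2)C2CCC(C(C)(C)C)CC2)cc1`, > 10000 nM

Both were tested in an in vitro assay on BHK cells for inhibition of Glucagon receptor (Homo sapiens); a lower number here means a stronger inhibitor, a higher number a weaker inhibitor. For compound 2 the result is a limit rather than a number, > 10000 nM, so compound 2 sits at the limit of > 10000 nM in this assay, at which 1 of the 2 values shown sits. Compound 1, which carries a carboxylic acid on its amide side chain and a different group on the outer ring, gives 140 nM in this assay . Compound 1 and compound 2 differ in more than one place, so only their two values can be set side by side, not a single step.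

Compound 3, `CC(C)(CC(=O)O)NC(=O)c1ccc(CN(C(=O)Nc2ccc(OC(F)(F)F)cc2)C2CCC(C(C)(C)C)CC2)cc1`, keeps the whole of compound 2 except for one exchange: 1-(carboxymethyl)-1-methylethyl in place of 3-methoxypropyl on an amide-type nitrogen. Going by the values given here, no measured pair shows this step, and compound 2 offers only a limit to start from. The expectation is that compound 3 improves on compound 2 by an at least 6.6-fold lower number from compound 2 to compound 3 (0.82 log units; beyond the scatter), well beyond the scatter, given that compound 1 with its acid reaches 140 nM. Compound 3 is estimated at 1500 nM, in the range 300 nM to 10000 nM.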

Compound 3, half-maximal inhibitory concentration: > 10000 nM
Compound 3: a limit, no number; the forecaster's own chance of this, stated with the estimate: 30%; middle value at least 6.6-fold (0.82 log units) from the limit.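

In this assay compound 3 gives > 10000 nM, which is a limit and not a number. Compound 2 also stands at a limit, so no step can be read between compound 2 and compound 3: the limit of > 10000 nM in this assay, at which 2 of the 3 values shown sit.

Left open is how far each compound lies past that limit, and whether 1-(carboxymethyl)-1-methylethyl in place of 3-methoxypropyl changes the result at all.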